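This account rests on a few compounds, and the source may have more. Where it says the series, first, only, none or still open, it means among the compounds named here.

Compound 1 `CCC1(Cc2ccccc2)OS(=O)(=O)C=C1OCc1ccc(OC)cc1` stands at a limit in an ADME assay on HEL cells (Homo sapiens) for cytotoxicity, with a stated time of 3 days; a lower number here means that less compound is tolerated, a higher number that more compound is tolerated: it gives > 200000 nM, which is a limit of the assay rather than a number. Compound 2 `CCC1(Cc2ccccc2)OS(=O)(=O)C=C1OCC1CCCCC1` likewise returns only the limit > 200000 nM. Compound 3 `CCC1(Cc2ccccc2)OS(=O)(=O)C=C1OCc1cccc(Cl)c1` gives a measured value of 50000 nM. The step that the two limits leave unreadable from compound 1 to compound 2 cannot be read because of the limit of > 200000 nM in this assay, at which 2 of the 3 values shown sit. The readable steps are an at least 4.0-fold lower number from compound 1 to compound 3 (0.60 log units; beyond the scatter) and an at least 4.0-fold lower number from compound 2 to compound 3 (0.60 log units; beyond the scatter). The unmeasured compound 4 `CCC1(Cc2ccccc2)OS(=O)(=O)C=C1OCc1ccc(C(F)(F)F)cc1` differs from compound 1 by trifluoromethyl in place of methoxy on an aromatic carbon. Within the data shown here, no measured step matches this change exactly, but the two readable steps both lowered the number when the group on the saturated chain carbon changed, so a modest fall from the limit is expected: an at least 2.0-fold lower number from compound 1 to compound 4 (0.30 log units; that floor lies within the scatter). Compound 4 is therefore estimated at 100000 nM, expected to lie between 30000 nM and 200000 nM.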

Compound 4, half-maximal cytotoxic concentration: 99000 nM
Compound 4: the middle estimate sits 1.0-fold (0.00 log units) above what was measured; the measured number falls inside the stated range.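

Unlike the earlier steps, which replaced the whole group on the saturated chain carbon, this one keeps the six-membered aromatic ring and changes only the group on its aromatic carbon para to a large group. In this assay, trifluoromethyl in place of methoxy gives an at least 2.0-fold lower number from compound 1 to compound 4 (0.30 log units; that floor lies within the scatter), so this single change moves the compound from a limit to a measured number. Only a floor can be stated for this step because compound 1 sits at a limit: the limit of > 200000 nM in this assay, at which 2 of the 4 values shown sit.

Going by these compounds, whether an amine or a nitrile on this aromatic carbon would behave alike remains open. So does the true size of the step.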